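From compound 3 to compound 4: working notes

A few compounds are considered here, and "the series" means these few. Any claim that something is new, unique, unknown or untested is made for them only; others in the source may bear on it.

In a functional assay on HL-60 cells (Homo sapiens) for inhibition, read by CCK-8 assay, with a stated time of 48 h (on this read-out lower numbers stand for stronger inhibition and higher numbers for weaker inhibition), compound 1 (`O=[N+]([O-])c1ccc(NC(=S)NCCNS(=O)(=O)c2ccc(-c3ccccc3OCc3ccccc3)s2)cc1`) reads > 50000 nM, which is a limit and not a number.

Compound 2 (`Cc1cc(C)cc(NC(=O)NCCNS(=O)(=O)c2ccc(-c3ccccc3OCc3ccccc3)s2)c1`) gives 2200 nM and compound 3 (`O=C(NCCNS(=O)(=O)c1ccc(-c2ccccc2OCc2ccccc2)s1)Nc1cc(Cl)cc(Cl)c1`) gives 11700 nM. Compound 3 therefore holds the higher of the two actual numbers, the gap being a 5.3-fold higher number from compound 2 to compound 3 (0.73 log units; beyond the scatter).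

Compound 4 (`O=S(=O)(NCCNC(=S)Nc1ccc(Cl)cc1)c1ccc(-c2ccccc2OCc2ccccc2)s1`) differs from compound 3 as follows: a group of 10 heavy atoms (7 carbon, 1 nitrogen, 1 sulfur, 1 chlorine; one six-membered aromatic ring of carbon only) in place of a group of 11 heavy atoms (7 carbon, 1 nitrogen, 1 oxygen, 2 chlorine; one six-membered aromatic ring of carbon only), on an amine nitrogen. The entering group holds sulfur where the leaving group holds oxygen, and the group on the same nitrogen in compound 1 also holds sulfur.

Two measured steps lead away from compound 1: an at least 22-fold lower number from compound 1 to compound 2 (1.35 log units; beyond the scatter), and an at least 4.2-fold lower number from compound 1 to compound 3 (0.63 log units; beyond the scatter). Read backwards, both suggest a higher number for a sulfur-bearing group, but compound 1 is the only such case measured, and its aromatic ring also carries a different substituent. Ring substitution alone can matter, as a 5.3-fold higher number from compound 2 to compound 3 (0.73 log units; beyond the scatter) shows.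

In this assay, a modest rise is therefore expected, and the estimated step is a 1.7-fold higher number from compound 3 to compound 4 (0.23 log units; within the scatter).

For compound 4 the estimated value is 20000 nM, with an expected range of 7000 nM to 50000 nM.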

Compound 4, half-maximal inhibitory concentration: > 50000 nM
Compound 4: no number, only a limit; the forecaster's own chance of this, stated with the estimate: 25%; middle value at least 2.5-fold (0.39 log units) from the limit.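

In this assay, the change on the amine nitrogen gives an at least 4.2-fold higher number from compound 3 to compound 4 (0.63 log units; beyond the scatter), and the comparison with the dimethyl analogue gives an at least 22-fold higher number from compound 2 to compound 4 (1.35 log units; beyond the scatter). Compound 1 is no longer the only sulfur-bearing compound at the top of the read-out, and a nitro group is not needed to reach it: the chloro-bearing compound 4 arrives there too, so among these four compounds the two with sulfur give limits and the two with a carbonyl oxygen give numbers, with none going against that split. The step between the two sulfur-bearing compounds cannot be read, and the result stands only as a shared ceiling: the limit of > 50000 nM in this assay, at which 2 of the 4 values shown sit.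

The step from compound 3 to compound 4 changes the oxygen to sulfur and the 3,5-dichlorophenyl ring to a ring with 1 chlorine at once, so the shares of the two changes stay unseparated. From the compounds shown here alone, it also remains open whether a methoxy group on the aromatic ring of a sulfur-bearing compound would bring a measurable number back, and how far above the limit compound 1 and compound 4 lie.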